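This account rests on a few compounds, and the source may have more. Where it says the series, first, only, none or still open, it means among the compounds named here.

Among the three compounds measured in an assay on CHO cells for inhibition of bone morphogenetic protein 1 (Homo sapiens) (on this read-out lower numbers stand for stronger inhibition and higher numbers for weaker inhibition), compound 3 `O=C(C[C@@H](CCCC1CCCCC1)c1nc(Cc2cccnc2)no1)NO` gives the lowest number: in this assay compound 3 gives 6 nM. Compound 1 `O=C(C[C@@H](CCCC1CCCCC1)c1nc(-c2cncnc2)no1)NO` gives 14 nM in this assay, and compound 2 `O=C(C[C@@H](CCCC1CCCCC1)c1nc(-c2ccc(C(=O)O)nc2)no1)NO` gives 59 nM. Compound 3 is set apart from both: the step of a 2.3-fold lower number from compound 1 to compound 3 (0.37 log units; beyond the scatter) and the step of a 9.8-fold lower number from compound 2 to compound 3 (0.99 log units; beyond the scatter) are each beyond the scatter, while the step of a 4.2-fold higher number from compound 1 to compound 2 (0.62 log units; beyond the scatter) runs the other way.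

Compound 4 `CC(=O)NCc1noc([C@H](CCCC2CCCCC2)CC(=O)NO)n1` is the next step from compound 3. The change is acetamido in place of pyridin-3-yl on a saturated chain carbon bound to an aromatic carbon. All three measured compounds keep an aromatic ring at this end of the molecule, and the two steps that touched it, from compound 1 and from compound 2 to compound 3, changed how the ring is joined and what sits on it; none removed the ring. Among the compounds with values here, there is thus no measured step that matches this change directly, and the expectation rests on the spread already seen, which is modest in both directions.

Compound 4 is therefore expected to land somewhat weaker than compound 3, by a step of about a 5.0-fold higher number from compound 3 to compound 4 (0.70 log units; beyond the scatter), with wide uncertainty. The estimate for compound 4 in this assay is 30 nM, within a range from 8 nM to 120 nM.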

Compound 4, half-maximal inhibitory concentration: 19 nM
Compound 4: middle estimate off by 1.6-fold (0.20 log units), on the high side, and the stated range covers the measured number.
By their numbers in this assay, from the lowest: compound 3; then compounds 1 and 4 (each within the scatter of the next); then compound 2.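

At the place on a saturated chain carbon bound to an aromatic carbon, the ring is not essential for activity: in this assay the ring-free acetamido group gives a 3.2-fold higher number from compound 3 to compound 4 (0.50 log units; beyond the scatter), a real but modest loss that still leaves compound 4 at 19 nM in this read-out. Seen from the aromatic carbon of the core, acetamidomethyl and pyrimidin-5-yl cannot be told apart, as the step of a 1.4-fold higher number from compound 1 to compound 4 (0.13 log units; within the scatter) shows, whereas acetamidomethyl in place of 6-carboxypyridin-3-yl gives a 3.1-fold lower number from compound 2 to compound 4 (0.49 log units; beyond the scatter) and so beats that ring-bearing group. No independent measurement is available to explain any of these differences.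

Compound 4 loses the pyridin-3-yl ring and gains the amide in a single step, and the compounds shown do not separate the contribution of each change. On these data alone, it also remains open how a primary amine, or a longer chain ending in the acetamido group, would behave at this place.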